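A few compounds are considered here, and "the series" means these few. Any claim that something is new, unique, unknown or untested is made for them only; others in the source may bear on it.

Compounds measured in a functional assay on MIA PaCa-2 cells (Homo sapiens) for inhibition, read by MTT assay, with a stated time of 3 days; on this read-out lower numbers stand for stronger inhibition and higher numbers for weaker inhibition:
compound 1, `CCN(CC)S(=O)(=O)c1ccc(S(=O)(=O)N2CCC[C@@H](C(=O)N3CCC(F)(F)CC3)C2)cc1`: 19 nM
compound 2, `CCN(CC)S(=O)(=O)c1ccc(S(=O)(=O)N2CCC[C@@H](C(=O)N3CCC(C(F)F)CC3)C2)cc1`: 140 nM

Going by the values given here, compound 1 holds the lowest of the two numbers in this assay; its only neighbour lies one step away, a 7.4-fold higher number from compound 1 to compound 2 (0.87 log units; beyond the scatter). Compound 3, `CN(C)S(=O)(=O)c1ccc(S(=O)(=O)N2CCC[C@@H](C(=O)N3CCC(F)(F)CC3)C2)cc1`, has not yet been measured. It differs from compound 1 in a single place: dimethylamino in place of diethylamino on a sulfonyl sulfur.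

Among the compounds with values here, the one measured step, from compound 1 to compound 2, exchanges the group on the carbonyl carbon and leaves the sulfonyl end of the molecule as it is, so it gives no direct guide to a change at the sulfonyl sulfur. Within the data shown here, no measured pair exchanges the diethylamino group for anything else. With nothing to point either way, the expectation is a step of about the size of the usual scatter, a 1.6-fold higher number from compound 1 to compound 3 (0.20 log units; within the scatter), with the number more likely to rise a little than to fall. Compound 3 is therefore estimated at 30 nM in this assay, with a range from 10 nM to 100 nM.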

Compound 3, half-maximal inhibitory concentration: 72.4 nM
Estimate against measurement, compound 3: 2.4-fold (0.38 log units) below; low and high end bracket the measured number.
By their numbers in this assay, from the lowest: compound 1; then compounds 3 and 2 (each within the scatter of the next).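

In this assay the sulfonyl sulfur proves to be a position that responds to substitution: dimethylamino in place of diethylamino gives a 3.8-fold higher number from compound 1 to compound 3 (0.58 log units; beyond the scatter) and so a change that removes only carbon from the amine on that sulfur is enough to carry the number past the scatter. The carbonyl carbon had already shown a step of this kind, a 7.4-fold higher number from compound 1 to compound 2 (0.87 log units; beyond the scatter) and the series now has one step beyond the scatter at each of the two places, both leading to higher numbers. Among the three compounds, compound 1, with diethylamino on the sulfonyl sulfur and 4,4-difluoropiperidin-1-yl on the carbonyl carbon, keeps the lowest number, and no measurement shown here explains why either change raises it.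

On these data alone, with a single pair at the sulfonyl sulfur, it remains open whether a longer chain such as dipropylamino, or a ring amine such as pyrrolidin-1-yl, would hold the number of compound 1, lower it or raise it. Also open, as far as these compounds go, is whether the step from diethylamino to dimethylamino keeps its size with 4-(difluoromethyl)piperidin-1-yl on the carbonyl carbon, since that change has been read only with 4,4-difluoropiperidin-1-yl in that place.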